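The compounds below may be only part of what the source reports. "The series", "measured", "known", "first", "only" and "open" are said of these compounds alone.

Measured so far in an assay for inhibition of Fatty-acid amide hydrolase 1 (Rattus norvegicus); on this read-out higher numbers stand for weaker inhibition and lower numbers for stronger inhibition:
compound 1 `CS(=O)(=O)c1cnc(C(=O)CCc2ccc(-c3ccccc3)cc2)o1`: 1.2 nM
compound 2 `O=C(CCc1ccc(COc2ccccc2)cc1)c1ncc(I)o1`: 4 nM

Of these two numbers, compound 1 has the lower one, and the gap between compound 1 and compound 2 lies beyond the usual scatter of repeated measurements; the two structures differ in more than one place, so nothing more than the two values themselves can be read from that gap.

Compound 3 `COC(=O)c1ccc(-c2cnc(C(=O)CCc3ccc(-c4ccccc4)cc3)o2)cn1` has not yet been measured. It differs from compound 1 in a single place: 6-(methoxycarbonyl)pyridin-3-yl in place of methylsulfonyl on an aromatic carbon. Among the measured compounds shown here, no measured pair shows a change of this kind, so the expectation for compound 3 rests on compound 1 alone, with the shared core and the rest of the molecule left untouched. The change from compound 1 to compound 3 is expected to bring a step of no change at the digits printed from compound 1 to compound 3 (within the scatter) in this assay, which is no step beyond the scatter in either direction. Compound 3 is therefore estimated to give 1.2 nM in this assay, with a range from 0.3 nM to 5 nM.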

Compound 3, inhibition constant: 0.6 nM
Compound 3: middle estimate off by 2.0-fold (0.30 log units), on the high side; the measured number falls inside the stated range.
By their numbers in this assay, from the lowest: compounds 3 and 1 (each within the scatter of the next); then compound 2.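

In this assay, putting 6-(methoxycarbonyl)pyridin-3-yl in place of methylsulfonyl on the aromatic carbon next to the ring oxygen gives a 2.0-fold lower number from compound 1 to compound 3 (0.30 log units; within the scatter), so this read-out does not separate the two compounds. This position therefore accepts two quite different groups without a step beyond the scatter: one of 4 heavy atoms with no ring, and one of 10 heavy atoms that brings a six-membered aromatic ring. No measurement at hand bears on why these two groups give matching numbers.

Going by these compounds, it remains open whether the methoxycarbonyl group matters at all, since a carboxylic acid or an amide in its place, or a pyridin-3-yl group with nothing on it, could give a similar number or a very different one. On these data alone, it is also open how far this acceptance reaches at this position, for instance to a simple amine or to a longer chain, and compound 2 cannot settle this, as it differs from compound 1 in more than one place.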